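Carboxy for methyl on the pyridine-bearing side of compound 2

This account rests on a few compounds, and the source may have more. Where it says the series, first, only, none or still open, it means among the compounds named here.

Measured compounds:
compound 1 `Cc1cccnc1-c1ccc(C(=O)Nc2ccc(C(F)(F)F)cc2)cc1` – 81 nM
compound 2 `Cc1cccnc1-c1ccc(C(=O)Nc2ccc(C(C)(C)C)cc2)cc1` – 9 nM
compound 3 `CCCOc1cccnc1-c1ccc(C(=O)Nc2ccc(C(C)(C)C)cc2)cc1` – 20 nM

In a functional assay for antagonist activity at transient receptor potential cation channel subfamily V member 1 (Rattus norvegicus) (on this read-out lower numbers stand for stronger inhibition and higher numbers for weaker inhibition), compound 2 gives the lowest of the three numbers; compound 3 comes nearest and compound 1 stands furthest away, both steps lying beyond the scatter. Two single-point steps connect the measured set: a 9.0-fold lower number from compound 1 to compound 2 (0.95 log units; beyond the scatter) and a 2.2-fold higher number from compound 2 to compound 3 (0.35 log units; beyond the scatter).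

Compound 4 `CC(C)(C)c1ccc(NC(=O)c2ccc(-c3ncccc3C(=O)O)cc2)cc1` is not yet measured. It differs from compound 2 by carboxy in place of methyl on an aromatic carbon. Among the measured compounds shown here, the step that bears on this is the one from compound 2 to compound 3, where propoxy in place of methyl at the same place cost a 2.2-fold higher number from compound 2 to compound 3 (0.35 log units; beyond the scatter). The step from compound 1 to compound 2 changes a different part of the core and says nothing direct about this position.

Since the change to carboxy is larger than the change to propoxy, a higher number in this assay is expected for compound 4, beyond the scatter, by an 11-fold higher number from compound 2 to compound 4 (1.05 log units; beyond the scatter). Compound 4 is therefore estimated at 100 nM, within a range from 20 nM to 800 nM.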

Compound 4, half-maximal inhibitory concentration: 560 nM
Beside the measured number, compound 4's estimate is 5.6-fold (0.75 log units) below it, and the stated range covers the measured number.
By their numbers in this assay, from the lowest: compound 2; then compound 3; then compound 1; then compound 4.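

In this assay the replacement of methyl by carboxy, on an aromatic carbon two atoms from the ring nitrogen, gives a 62-fold higher number from compound 2 to compound 4 (1.79 log units; beyond the scatter) and so shows that this position can lose far more than the modest step seen with propoxy had suggested. Carboxy in place of propoxy gives a 28-fold higher number from compound 3 to compound 4 (1.45 log units; beyond the scatter) and shows that the groups entering here are far from interchangeable, with propoxy staying much closer to methyl than carboxy does. No measurement in hand explains why carboxy costs so much at this place.

From the compounds shown here alone, it remains open whether a methyl ester or a primary amide, which would keep the carbonyl without the acid hydrogen, would stay close to propoxy or fall towards carboxy. An amine or a longer alkoxy chain at this position is equally untested in the compounds shown here.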